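Series notes: pyrimidin-2-yl in place of pyridin-2-yl

A few compounds are considered here, and "the series" means these few. Any claim that something is new, unique, unknown or untested is made for them only; others in the source may bear on it.

Measured compounds:
Compound 1, `Cc1ncc([N+](=O)[O-])n1CC(O)CSC(=S)N1CCN(c2ccccc2)CC1`. In a toxicity assay on HeLa cells (Homo sapiens) for cytotoxicity, read by MTT assay, with a stated time of 24 h (a higher number here means a weaker inhibitor, a lower number a stronger inhibitor), compound 1 gives > 5000000 nM, which is a limit of the assay and not a number.
Compound 2, `COc1ccccc1N1CCN(C(=S)SCC(O)Cn2c([N+](=O)[O-])cnc2C)CC1`. In this assay compound 2 gives > 5000000 nM, again a limit of the assay.
Compound 3, `Cc1ncc([N+](=O)[O-])n1CC(O)CSC(=S)N1CCN(c2ccccn2)CC1`. In this assay compound 3 gives 2970000 nM.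

Going by the values given here, compound 3 thus holds the only number in this assay; the other two values sit at a limit, (the limit of > 5000000 nM in this assay, at which 2 of the 3 values shown sit). The next compound, compound 4, `Cc1ncc([N+](=O)[O-])n1CC(O)CSC(=S)N1CCN(c2ncccn2)CC1`, differs from compound 3 by pyrimidin-2-yl in place of pyridin-2-yl on an amine nitrogen in a ring. Among the compounds with values here, the steps that bear on this change in the group on the ring nitrogen are small: an at least 1.6-fold lower number from compound 1 to compound 3 (0.22 log units; that floor lies within the scatter) and an at least 1.6-fold lower number from compound 2 to compound 3 (0.22 log units; that floor lies within the scatter), while a step that the two limits leave unreadable from compound 1 to compound 2. Neither measured step reaches beyond the scatter, so no step beyond the scatter is expected here: the expected step is a 1.0-fold higher number from compound 3 to compound 4 (0.00 log units; within the scatter). Compound 4 is therefore estimated at 3000000 nM, with a range from 1500000 nM to 6000000 nM, and a fair chance that this assay reports only a limit for compound 4.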

Compound 4, half-maximal inhibitory concentration: 2040000 nM
Compound 4: middle estimate off by 1.5-fold (0.17 log units), on the high side; low and high end bracket the measured number.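

In this assay, pyrimidin-2-yl cannot be told apart from pyridin-2-yl on the amine nitrogen in the ring: a 1.5-fold lower number from compound 3 to compound 4 (0.16 log units; within the scatter). Set against phenyl and 2-methoxyphenyl, however, pyrimidin-2-yl gives the first steps in this series that lie beyond the scatter, an at least 2.4-fold lower number from compound 1 to compound 4 (0.38 log units; beyond the scatter) and an at least 2.4-fold lower number from compound 2 to compound 4 (0.38 log units; beyond the scatter), whereas the floors of the steps to compound 3 stayed within it. Both new steps are floors that start from a limit of the assay and not from a number: the limit of > 5000000 nM in this assay, at which 2 of the 4 values shown sit.

The true size of these two steps stays open, and the compounds shown cannot say how far the steps reach. Also open, going by these compounds, is whether a benzyl or an acetyl group on the same amine nitrogen would give a value in the same range.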